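Changing One Ring Stereocentre at the Half-Life Limit

The source may report more compounds than this note shows. Statements on the series, on what has been measured and on what is new or still open speak of the compounds shown alone.

- Compound 1 `O=C(O)[C@@H](CO)NC(=O)[C@H]1C[C@@H](O)CN1` in a physicochemical assay for metabolic stability, read by HPLC, with a stated time of 12 h, at pH 1.2 (on this read-out higher numbers stand for a longer-lived compound and lower numbers for a shorter-lived compound), gives > 12 h as a limit
- Compound 2 `O=C(O)[C@@H](CO)NC(=O)[C@H]1C[C@H](O)CN1` in this assay gives > 12 h as a limit

Compound 2 stands at the limit of > 12 h in this assay, at which 2 of the 2 values shown sit, and so has a limit, not a number. Compound 3 `O=C(N[C@H](CO)C(=O)O)[C@@H]1C[C@H](O)CN1` differs from compound 2 as follows (the two compounds have the same atoms and bonds and differ only in configuration as drawn: 1 of 3 stereo elements differ; a stereocentre at a saturated ring carbon is drawn R in compound 2 and S in compound 3) and nothing leaves or enters. Among the measured compounds shown here, the one measured step that bears on this is a step that the two limits leave unreadable from compound 1 to compound 2 and it too is a change at a saturated ring carbon. Its size cannot be read, so no step beyond the scatter is expected in this assay and no direction is expected either. The expected step is a step that the limit leaves unreadable from compound 2 to compound 3 at this estimate. For compound 3 the estimated half-life is 15 h (range 12 h to 30 h) and only a limit will probably be reported.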

Compound 3, half-life: > 12 h
Compound 3 gave a limit, no number; the forecaster's own chance of this, stated with the estimate: 90%; the middle value does not contradict the limit.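

In this assay, among the compounds shown here, compound 1, compound 2 and compound 3 all sit at the same limit, and no step between them can be read. The compounds shown leave open whether changing these stereocentres alters the half-life at all.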